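This account rests on a few compounds, and the source may have more. Where it says the series, first, only, none or still open, it means among the compounds named here.

Working notes on the series. Of the compounds shown here, two have been measured. Compound 1 `O=C(/C=C/c1ccc(N2CCCCC2)cc1)c1cccs1` carries the thiophene on an open chain through a carbonyl; compound 2 `c1csc(C2=NNC(c3ccc(N4CCCCC4)cc3)C2)c1` closes that chain into the shared core. In an ADME assay on PBMC cells (Homo sapiens) for cytotoxicity, with a stated time of 5 days (a lower number here means a stronger inhibitor, a higher number a weaker inhibitor), compound 2 gives 20800 nM. For compound 1 this assay reports only a limit, > 100000 nM, not a number. Among the compounds with values here, compound 2 thus stands as the one measured number in this assay, the other entry being (the limit of > 100000 nM in this assay, at which 1 of the 2 values shown sits). Within the data shown here, no measured pair differs in a single place, so no measured step is available to set a scale.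

Compound 3 `Cc1ccsc1C1=NNC(c2ccc(N3CCCCC3)cc2)C1` is the next to be tested. It differs from compound 2 in one place: methyl in place of hydrogen on an aromatic carbon of the five-membered ring with one sulfur. Nothing measured bears on this change. The step from compound 2 to compound 3 is expected to be small, a 1.0-fold lower number from compound 2 to compound 3 (0.02 log units; within the scatter), and not beyond the scatter of this assay. Compound 3 is therefore estimated at 20000 nM, within 7000 nM to 60000 nM.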

Compound 3, half-maximal inhibitory concentration: 11000 nM
The estimate for compound 3 lay 1.8-fold (0.26 log units) above the measured number; the measured number falls inside the stated range.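

Within the data shown here, this is the first measured single-place step: methyl in place of hydrogen on an aromatic carbon of the five-membered aromatic ring with 1 sulfur gives a 1.9-fold lower number from compound 2 to compound 3 (0.28 log units; within the scatter) in this assay. At this place, next to the ring atom that bears a large group and two ring bonds from the ring sulfur, the change from thiophen-2-yl to 3-methylthiophen-2-yl therefore stays within the scatter, and the series now has one measured scale for a change of a single heavy atom. Nothing measured here bears on the reason for the size of this step.

From the compounds shown here alone, whether a longer chain such as ethyl, or an amine, at this same place would also stay within the scatter remains open, as does the effect of methyl on the other carbons of that ring. Going by these compounds, with a single step in hand, it is also open whether a change at any other part of the shared core would move the number in this assay further than this one does.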